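This account rests on a few compounds, and the source may have more. Where it says the series, first, only, none or still open, it means among the compounds named here.

Compound 2, `CCCc1ccc(NC(=O)N[C@@H](C)c2ccccc2)cc1`, gives 97% in an ADME assay on the whole organism with Oryza sativa as the target, tested at 0.1 uM (on this read-out higher numbers stand for a weaker effect at the one concentration tested and lower numbers for a stronger effect), and stands second highest of the three numbers measured; compound 3, `C[C@@H](NC(=O)Nc1cccc(F)c1)c1ccccc1`, gives 99% within the scatter of it, whereas compound 1, `CCCc1ccc(NC(=O)N[C@H](C)c2ccccc2)cc1`, gives 33%, and the step of a number 64 percentage points higher from compound 1 to compound 2 (beyond the scatter) is large and is tied to the fact that (the fact that compounds 1 and 2 differ only in the configuration as drawn). Compound 4, `C[C@H](NC(=O)Nc1ccc(Br)cc1)c1ccccc1`, differs from compound 2 by bromo in place of propyl on an aromatic carbon. Among the measured compounds shown here, none of the measured steps changes a ring substituent, so none bears directly on this swap; the only measured step concerns configuration. With no evidence for a substituent effect, compound 2 is taken as the anchor and a step of a number 4 percentage points lower from compound 2 to compound 4 (within the scatter) is expected, not beyond the scatter. Compound 4 is therefore estimated at 93%, between 70% and 100%.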

Compound 4, a percentage reported as activity, at one concentration (the size of the read-out at that concentration, not a potency): 98%
Compound 4: middle estimate off by 5 percentage points, on the low side; the measured number falls inside the stated range.
By their numbers in this assay, from the lowest: compound 1; then compounds 2, 4 and 3 (each within the scatter of the next).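

In this assay, bromo in place of propyl on an aromatic carbon, para to a large group, gives a number 1 percentage points higher from compound 2 to compound 4 (within the scatter) and is the first ring-substituent step shown. For this pair, the swap leaves the read-out within the scatter, so a propyl group is not needed at this position to keep the number where compound 2 has it. Nothing measured here accounts for this result.

As far as these compounds go, it remains open whether the same swap would matter in the configuration of compound 1, which gives 33% in this assay. From the compounds shown here alone, it is also open whether an amine, a carboxylic acid or a longer chain at this position would move the number.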